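The source may hold more compounds than are shown below. What is called first, only, known or untested is meant among the compounds shown, and "the series" means these compounds.

Measured in an ADME assay on J774.A1 cells (Mus musculus) for cytotoxicity, read by MTT assay, with a stated time of 48 h; on this read-out higher numbers stand for lower toxicity in this test and lower numbers for higher toxicity in this test:
- compound 1 `COc1ccc(/C=C(\C)C(=O)/C=C/c2ccccc2)cc1`: 54000 nM
- compound 2 `COc1ccc(/C=C(\C)C(=O)/C=C/c2ccc(N(C)C)cc2)cc1`: 36200 nM
- compound 3 `C/C(=C\c1ccc([N+](=O)[O-])cc1)C(=O)/C=C/c1ccccc1`: 47300 nM

Compound 3 stands within the scatter of both compound 1 and compound 2, so these three values give no order. Compound 4 `C/C(=C\c1ccc([N+](=O)[O-])cc1)C(=O)/C=C/c1ccc(N(C)C)cc1` has dimethylamino in place of hydrogen on an aromatic carbon of compound 3: dimethylamino in place of hydrogen on an aromatic carbon.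

The one measured case of this exchange is a 1.5-fold lower number from compound 1 to compound 2 (0.17 log units; within the scatter). The nitro for methoxy exchange, a 1.1-fold lower number from compound 1 to compound 3 (0.06 log units; within the scatter), is the other measured step. On this evidence, no step beyond the scatter is expected in this assay, and the expected result is a 1.3-fold lower number from compound 3 to compound 4 (0.12 log units; within the scatter). For compound 4 the estimated value is 36000 nM, with an expected range of 20000 nM to 62000 nM.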

Compound 4, half-maximal cytotoxic concentration: 24700 nM
For compound 4 the middle estimate is 1.5-fold (0.16 log units) above the measured one, and the stated range covers the measured number.
By their numbers in this assay, from the lowest: compounds 4, 2, 3 and 1 (each within the scatter of the next, the first and the last beyond it).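

In this assay dimethylamino in place of hydrogen on an aromatic carbon now has a second reading with a 1.9-fold lower number from compound 3 to compound 4 (0.28 log units; within the scatter) and so no longer rests on a single case: the same change on two cores in this assay, a 1.5-fold lower number (0.17 log units; within the scatter) from compound 1 to compound 2 and a 1.9-fold lower number (0.28 log units; within the scatter) from compound 3 to compound 4, 1.3-fold (0.11 log units) apart, within the scatter of two such steps.
Nitro in place of methoxy likewise has a second reading with a 1.5-fold lower number from compound 2 to compound 4 (0.17 log units; within the scatter) on a core carrying dimethylamino: the same change on two cores in this assay, a 1.1-fold lower number (0.06 log units; within the scatter) from compound 1 to compound 3 and a 1.5-fold lower number (0.17 log units; within the scatter) from compound 2 to compound 4, 1.3-fold (0.11 log units) apart, within the scatter of two such steps.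
Neither exchange gives a step beyond the scatter on either core.

As far as these compounds go, whether a morpholine or a longer-chain amine in place of dimethylamino would give a step beyond the scatter stays open. So does the effect of a carboxylic acid in place of nitro.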